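The source may hold more compounds than are shown below. What is called first, only, known or untested is meant among the compounds shown, and "the series" means these compounds.

The series shares one core, seen in compound 1 `COc1cc(-c2nn(-c3ccccc3)cc2C(=O)/C=C\Nc2ccc(Cl)cc2)cc(OC)c1OC`, which carries chloro on an aromatic carbon and gives 3210 nM in a functional assay on U-87MG ATCC cells (Homo sapiens) for antiproliferative activity, read by MTT assay, with a stated time of 48 h; on this read-out higher numbers stand for weaker inhibition and lower numbers for stronger inhibition. Compound 2 `COc1cc(-c2nn(-c3ccccc3)cc2C(=O)/C=C\Nc2ccc(C(F)(F)F)cc2)cc(OC)c1OC` carries trifluoromethyl in place of that chloro; in this assay compound 2 reaches only > 50000 nM, which is a limit of the assay and not a number. On the numbers shown, compound 2 thus stands at a limit (the limit of > 50000 nM in this assay, at which 1 of the 2 values shown sits), and the step of an at least 15-fold higher number from compound 1 to compound 2 (1.19 log units; beyond the scatter) is known only as a bound. Compound 3 `COc1ccc(N/C=C\C(=O)c2cn(-c3ccccc3)nc2-c2cc(OC)c(OC)c(OC)c2)cc1` is compound 2 with methoxy in place of trifluoromethyl on an aromatic carbon. Going by the values given here, no measured step compares methoxy with any other group here; the single step in hand, an at least 15-fold higher number from compound 1 to compound 2 (1.19 log units; beyond the scatter), shows that the group at this aromatic carbon can shift the read-out by a large amount, but it concerns chloro and trifluoromethyl only. The estimated step of an at least 5.0-fold lower number from compound 2 to compound 3 (0.69 log units; beyond the scatter) is expected to be a decrease from the limit, with wide uncertainty. Compound 3 is estimated at 10000 nM, between 2000 nM and 50000 nM.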

Compound 3, half-maximal inhibitory concentration: 12800 nM
Compound 3: middle estimate off by 1.3-fold (0.11 log units), on the low side, within the range that was stated.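

In this assay, methoxy in place of trifluoromethyl gives an at least 3.9-fold lower number from compound 2 to compound 3 (0.59 log units; beyond the scatter), so the position can hold a group other than chloro and still return a measurable number, where trifluoromethyl did not. Methoxy in place of chloro gives a 4.0-fold higher number from compound 1 to compound 3 (0.60 log units; beyond the scatter), the first step at this aromatic carbon read between two actual numbers, and it shows that both replacements of chloro shown so far raise the number, by different amounts, with methoxy falling between chloro and trifluoromethyl. Compound 2 stands as a limit and not a number, so the size of the step to methoxy is known only as a bound: the limit of > 50000 nM in this assay, at which 1 of the 3 values shown sits.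

The compounds shown leave open how a group such as bromo, methyl or an amine on this carbon would compare with chloro, and whether any group here would give a lower number than compound 1. They also leave open whether the order of chloro, methoxy and trifluoromethyl would hold with these groups on another carbon of the same ring or with the rest of the shared core changed.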